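A thiophene in place of the sulfamoylphenyl

The compounds below may be only part of what the source reports. "The series", "measured", "known", "first", "only" and "open" are said of these compounds alone.

Compound 1 `N#Cc1ccc(F)cc1Cn1c(N2CCC[C@@H](N)C2)nc2c(-c3ccc(S(N)(=O)=O)cc3)c[nH]c2c1=O` is measured in an ADME assay on microsomes from liver (Homo sapiens) for metabolic stability, read by LC-MS, tested at 1 mM; on this read-out lower numbers stand for a shorter-lived compound and higher numbers for a longer-lived compound. For compound 1 the assay returns only a limit, > 3.33 h. Compound 3 `CS(=O)(=O)c1ccc(-c2c[nH]c3c(=O)n(Cc4cc(F)ccc4C#N)c(N4CCC[C@@H](N)C4)nc23)cc1F` likewise sits at a limit, > 3.33 h. Compound 2 `N#Cc1ccc(F)cc1Cn1c(N2CCC[C@@H](N)C2)nc2c(-c3ccc(F)cc3)c[nH]c2c1=O` gives 3.01 h. The step of an at least 1.1-fold lower number from compound 1 to compound 2 (0.04 log units; that floor lies within the scatter) and the step of an at least 1.1-fold higher number from compound 2 to compound 3 (0.04 log units; that floor lies within the scatter) both lie within the scatter, while the step that the two limits leave unreadable from compound 1 to compound 3 cannot be sized because the limit of > 3.33 h in this assay, at which 2 of the 3 values shown sit, caps two of the three values. Compound 4 `N#Cc1ccc(F)cc1Cn1c(N2CCC[C@@H](N)C2)nc2c(-c3ccsc3)c[nH]c2c1=O` differs from compound 1 by thiophen-3-yl in place of 4-sulfamoylphenyl on an aromatic carbon. Among the measured compounds shown here, no measured step exchanges the aryl group for a five-membered ring, so the measured steps bear on it only in that none of them moved beyond the scatter. Compound 4 is therefore expected to give 2.6 h, between 1.3 h and 3.33 h, a step of an at least 1.2-fold lower number from compound 1 to compound 4 (0.10 log units; that floor lies within the scatter) expected to stay within the scatter.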

Compound 4, half-life: 2.67 h
Estimate against measurement, compound 4: 1.0-fold (0.01 log units) below, and the stated range covers the measured number.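

In this assay, the place on the five-membered aromatic ring also accepts thiophen-3-yl, which has fewer heavy atoms than 4-sulfamoylphenyl and no sulfonyl group, with a 1.1-fold lower number from compound 2 to compound 4 (0.05 log units; within the scatter). A six-membered ring is therefore not needed there to stay within the scatter of compound 2. The other two readings, an at least 1.2-fold lower number from compound 1 to compound 4 (0.09 log units; that floor lies within the scatter) and an at least 1.2-fold lower number from compound 3 to compound 4 (0.09 log units; that floor lies within the scatter), are only floors, so their full size cannot be read: the limit of > 3.33 h in this assay, at which 2 of the 4 values shown sit.

Going by these compounds, it remains open how a furan, a pyridine or a carboxylic acid at this place would read. On these data alone, it also remains open whether any group there moves the half-life beyond the scatter.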